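Removing the iodo group from compound 2

The source may report more compounds than this note shows. Statements on the series, on what has been measured and on what is new or still open speak of the compounds shown alone.

Measured compounds and their values:
- compound 1, `COc1ccc(/C=C\C(=O)O)c(OCc2cn(-c3ccccc3C(=O)N3CCC(O)C3)nn2)c1CC=C(C)C`: 32000 nM
- compound 2, `COc1ccc(/C=C\C(=O)O)c(OCc2cn(-c3ccccc3I)nn2)c1CC=C(C)C`: 23100 nM
- compound 3, `COc1ccc(-n2cc(COc3c(/C=C\C(=O)O)ccc(OC)c3CC=C(C)C)nn2)cc1`: 8700 nM

These three compounds share one core and differ only in the group attached to the aromatic nitrogen of the triazole. In a functional assay on HCT-116 cells (Homo sapiens) for cytotoxicity, read by MTT assay, with a stated time of 24 h (a higher number here means a weaker inhibitor, a lower number a stronger inhibitor), compound 2 gives 23100 nM, the second highest of the three numbers; it sits close to compound 1, with a 1.4-fold lower number from compound 1 to compound 2 (0.14 log units; within the scatter), and furthest from compound 3, with a 2.7-fold lower number from compound 2 to compound 3 (0.42 log units; beyond the scatter).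

Compound 4, `COc1ccc(/C=C\C(=O)O)c(OCc2cn(-c3ccccc3)nn2)c1CC=C(C)C`, is not yet measured. Its change from compound 2 is hydrogen in place of iodo on an aromatic carbon. Among the compounds with values here, two measured steps bear on this. The step from compound 1 to compound 2 swaps one substituent for another on the same aromatic carbon, and the number barely moves. The step from compound 2 to compound 3 replaces the whole aryl group and gives a modest gain. Taking a substituent away altogether is a smaller change than either, so the expected step in this assay is small and probably within the scatter, in either direction.

Compound 4 is therefore expected to give about 22000 nM, with a plausible range from 10000 nM to 48000 nM. The expected step from compound 2 is a 1.1-fold lower number from compound 2 to compound 4 (0.02 log units; within the scatter).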

Compound 4, half-maximal inhibitory concentration: 26000 nM
Compound 4: the middle estimate sits 1.2-fold (0.07 log units) below what was measured; the range from low to high includes it.
By their numbers in this assay, from the lowest: compound 3; then compounds 2, 4 and 1 (each within the scatter of the next).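

In this assay, this aromatic carbon, ortho to a large group, shows little sensitivity to what it carries: with hydrogen in place of iodo there is a 1.1-fold higher number from compound 2 to compound 4 (0.05 log units; within the scatter) and with hydrogen in place of the much larger (3-hydroxypyrrolidin-1-yl)carbonyl group there is a 1.2-fold lower number from compound 1 to compound 4 (0.09 log units; within the scatter) so the plain phenyl compound cannot be told apart from either substituted one. Within the data shown here, the methoxy group behaves differently, with a 3.0-fold higher number from compound 3 to compound 4 (0.48 log units; beyond the scatter) and this is the only one of the new steps beyond the scatter, so the plain phenyl ring now serves as a baseline against which compound 3 alone stands out. No measurement is available that would explain either the flat result at this carbon or the difference seen with the methoxy group.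

On these data alone, what an amine or a carboxylic acid would do on the carbon that carries the iodo group in compound 2 remains open, as does whether a methoxy group on that same carbon would match compound 3. As far as these compounds go, it is also open whether this pattern holds outside this assay in other cell lines or at other exposure times.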